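This account rests on a few compounds, and the source may have more. Where it says the series, first, only, none or still open, it means among the compounds named here.

Series read in a functional assay on NCI/ADR-RES cells (Homo sapiens) for inhibition, read by sulforhodamine B assay, with a stated time of 48 h, tested at 10 uM; a higher number here means more inhibition of growth at the concentration tested, a lower number less inhibition of growth:
- compound 1 `COc1ccc(-c2nc3sc(-c4ccccc4)cn3n2)cc1`: 66%
- compound 2 `COc1cc(-c2nc3sc(-c4ccccc4)cn3n2)cc(OC)c1OC`: 39%
- compound 3 `Clc1ccc(-c2cn3nc(-c4ccccc4)nc3s2)cc1`: 34%

Compound 3, at 34%, lies within the scatter of compound 2, at 39%. Compound 1 reads 66%. Compound 3 lies lower than compound 1, and that gap is beyond the scatter.

The next compound to be read is compound 4 `COc1ccc(-c2nc3sc(-c4ccc(Cl)cc4)cn3n2)cc1`. Relative to compound 3, it has methoxy in place of hydrogen on an aromatic carbon of a six-membered aromatic ring of carbon only, para to a large group: methoxy in place of hydrogen on an aromatic carbon.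

For the measured compounds named here, no two measured compounds differ in one place only, so the size of this change has no direct measure. The indirect evidence is mixed. Compound 1 also carries a methoxy and reads 66%, which points upward from compound 3. Against that, compound 2 also carries methoxy groups and reads 39%, within the scatter of compound 3. A moderate rise is therefore expected, with no change beyond the scatter remaining possible. The expected move is a number 16 percentage points higher from compound 3 to compound 4 (beyond the scatter). For compound 4 the estimated value is 50%, with an expected range of 30% to 72%.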

Compound 4, percent growth inhibition at one concentration: 54.4%
Compound 4: the middle estimate sits 4.4 percentage points below what was measured; low and high end bracket the measured number.
By their numbers in this assay, from the lowest: compounds 3 and 2 (each within the scatter of the next); then compound 4; then compound 1.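

In this assay, the series now has its first comparisons in which one place alone changes, and both are beyond the scatter. With chloro held on one six-membered aromatic ring of carbon only, methoxy in place of hydrogen on the other gives a number 20.4 percentage points higher from compound 3 to compound 4 (beyond the scatter), a direct measure of the gain from this group at this position, para to a large group. With methoxy held, chloro in place of hydrogen on the first ring runs the opposite way, a number 11.6 percentage points lower from compound 1 to compound 4 (beyond the scatter), so the two groups pull in opposite directions and compound 4, which carries both, keeps much of the gain while still reading under the chloro-free compound; no measurement at hand accounts for either step.

Going by these compounds, it remains open whether the rise belongs to methoxy specifically or would also appear with hydroxy, an amine or a longer ether chain such as ethoxy at the same position. On these data alone, it is also open whether the loss is particular to chloro, or would recur with fluoro or methyl on that ring.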